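A few compounds are considered here, and "the series" means these few. Any claim that something is new, unique, unknown or untested is made for them only; others in the source may bear on it.

Of the compounds shown here, three built on the shared core have been measured in a functional assay on HCT-116 cells (Homo sapiens) for antiproliferative activity, read by sulforhodamine B assay, with a stated time of 72 h; a lower number here means a stronger inhibitor, a higher number a weaker inhibitor. There, compound 1 (`COc1ncc(-c2ccc3c(c2)N(Cc2ccc(F)cc2)C(=O)CO3)cc1NS(=O)(=O)c1ccc(F)cc1F`) gives 1240 nM and compound 2 (`COc1ncc(-c2ccc3c(c2)N(Cc2ccncc2)C(=O)CO3)cc1NS(=O)(=O)c1ccc(F)cc1F`) gives 2220 nM. Compound 3 (`CCCCS(=O)(=O)Nc1cc(-c2ccc3c(c2)N(Cc2ccncc2)C(=O)CO3)cnc1OC`) gives 41400 nM, the highest number of the three, which makes it the weakest inhibitor of this small set.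

Compound 4 (`CCCCS(=O)(=O)Nc1cc(-c2ccc3c(c2)N(CCC(=O)N2CCOCC2)C(=O)CO3)cnc1OC`) keeps the butyl on the sulfonyl sulfur of compound 3 and changes one group: ((morpholin-4-yl)carbonyl)methyl in place of pyridin-4-yl on a saturated chain carbon bound to an amide-type nitrogen in a ring. Put simply, ((morpholin-4-yl)carbonyl)methyl takes the place of pyridin-4-yl on a saturated chain carbon bound to an amide-type nitrogen in a ring.

Two measured steps are worth weighing. The step at this same place, with pyridin-4-yl in place of 4-fluorophenyl, is a 1.8-fold higher number from compound 1 to compound 2 (0.25 log units; within the scatter), and it is the basis for expecting little change here. The other step, with butyl in place of 2,4-difluorophenyl on a sulfonyl sulfur, is a 19-fold higher number from compound 2 to compound 3 (1.27 log units; beyond the scatter). It is large, but it concerns a part of the molecule that stays the same in this change. Within the data shown here, only one step at the changing place has been measured, and the entering group resembles neither earlier group, so the range must stay wide.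

In this assay the expected step is a 1.0-fold lower number from compound 3 to compound 4 (0.01 log units; within the scatter), with no move beyond the scatter anticipated. For compound 4 the estimated value is 40000 nM, with an expected range from 13000 nM to 120000 nM.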

Compound 4, half-maximal inhibitory concentration: 23500 nM
Compound 4: middle estimate off by 1.7-fold (0.23 log units), on the high side, and the stated range covers the measured number.
By their numbers in this assay, from the lowest: compounds 1 and 2 (each within the scatter of the next); then compounds 4 and 3 (each within the scatter of the next).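

In this assay, the earlier step at this place only swapped one aromatic ring for another, and it did so with 2,4-difluorophenyl on the sulfonyl sulfur. This result extends the picture to a very different kind of group: with butyl on the sulfonyl sulfur, replacing pyridin-4-yl with ((morpholin-4-yl)carbonyl)methyl, which brings a non-aromatic ring and a carbonyl, gives a 1.8-fold lower number from compound 3 to compound 4 (0.25 log units; within the scatter). Both steps measured at this place therefore stay within the scatter, so across these two pairs the number does not respond clearly to the identity of the group, although compound 3 and compound 4 both sit far up in the weak range, and no supporting measurement is available to explain this.

Going by these compounds, it remains open whether ((morpholin-4-yl)carbonyl)methyl would behave the same way with 2,4-difluorophenyl on the sulfonyl sulfur, where the numbers are much lower and a change might be easier to see. Also open, on these data alone, is what a carboxylic acid, a primary amine or a longer chain would do at this place, since a charged or simpler group could yet separate itself from those seen here.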